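The source may hold more compounds than are shown below. What is called first, only, known or untested is meant among the compounds shown, and "the series" means these compounds.

Series around the shared core of compound 1 `CC(C)(C)OC(=O)N1CCN(c2ccc(OCc3ccc(S(C)(=O)=O)cc3)cn2)CC1`, tested in an in vitro functional assay on HEK293S cells for agonist activity at Glucose-dependent insulinotropic receptor (Homo sapiens), read by HTRF and cAMP accumulation, with a stated time of 45 min; on this read-out lower numbers stand for an effect already at smaller amounts and higher numbers for an effect only at larger amounts of compound. Compound 1 gives 186 nM. Compound 2 `Cc1cc(COc2cnc(N3CCN(C(=O)OC(C)(C)C)CC3)nc2)ccn1` carries a different core. For compound 2 the assay records only a limit, > 1930 nM. Where compound 2 stands is therefore set by the limit of > 1930 nM in this assay, at which 1 of the 2 values shown sits: an edge of the assay, not a number. Among the measured compounds shown here, the values of compound 1 and compound 2 show compound 1 with a number and compound 2 at the limit; no step between them is drawn, since the cores differ.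

Compound 3 `COc1cnccc1COc1cnc(N2CCN(C(=O)OC(C)(C)C)CC2)nc1` departs from compound 2 by 3-methoxypyridin-4-yl in place of 2-methylpyridin-4-yl on a saturated chain carbon bound to an oxygen on an aromatic ring. For the measured compounds named here, no measured step of this kind exists in the set, so the expectation rests on compound 2 alone, which sits at the limit > 1930 nM. Compound 3 is expected to stay near that edge, the implied step that the limit leaves unreadable from compound 2 to compound 3 having no clear direction beyond the scatter. The estimate for compound 3 is 2500 nM, with a range from 800 nM to 8000 nM.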

Compound 3, half-maximal effective concentration in the Glucose-dependent insulinotropic receptor assay: 1930 nM
For compound 3 the middle estimate is 1.3-fold (0.11 log units) above the measured one; low and high end bracket the measured number.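

In the Glucose-dependent insulinotropic receptor assay compound 3 gives a number, 1930 nM, with 3-methoxypyridin-4-yl on a saturated chain carbon bound to an oxygen on an aromatic ring. In the Glucose-dependent insulinotropic receptor assay compound 2 has only a limit, > 1930 nM, which is an edge of the assay and not a number. The change in the Glucose-dependent insulinotropic receptor assay reads as a number no higher from compound 2 to compound 3 (the limit leaves the size open) and its size cannot be read. In a physicochemical assay for solubility, in phosphate buffer, at pH 7.4 (a higher number here means a more soluble compound, a lower number a less soluble compound), compound 2 gives 66000 nM and compound 3 gives 11000 nM so the same change does register there: the measured solubility of compound 2, 66000 nM, and of compound 3, 11000 nM, a 6.0-fold lower number (0.78 log units; beyond the scatter)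

The compounds shown leave open how the methoxy group entering and the methyl group leaving would act apart in the Glucose-dependent insulinotropic receptor assay or in the physicochemical assay. Also open, going by these compounds, is how a dimethylamino group or a carboxylic acid in place of the methoxy group of 3-methoxypyridin-4-yl would read in the Glucose-dependent insulinotropic receptor assay.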